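The compounds below may be only part of what the source reports. "The series", "measured", "known", "first", "only" and "open" are said of these compounds alone.

Working notes on the series. Compound 1 `CCN1CCN(CCCn2cnc3c(N4CCN(CC)CC4)ncnc32)CC1` is the weakest of the three measured compounds: in an assay on HEK293 cells for antagonist activity at Toll-like receptor 9 (Homo sapiens), read by spectrophotometry (a lower number here means a stronger inhibitor, a higher number a weaker inhibitor), compound 1 gives 1190 nM, the highest of the three numbers. Compound 3 `CCN1CCN(c2nc(N)nc3c2ncn3CCCN2CCCC2)CC1` gives 190 nM in this assay, and compound 2 `Fc1ccc(CNc2nc(N3CCN(C4CCCC4)CC3)c3ncn(CCCN4CCCC4)c3n2)cc1` gives 100 nM; both gaps to compound 1 lie beyond the usual scatter.

Compound 4 `CCN1CCN(CCCn2cnc3c(N4CCN(CC)CC4)nc(NCc4ccccc4)nc32)CC1` is not yet measured. It differs from compound 1 by benzylamino in place of hydrogen on an aromatic carbon. For the measured compounds named here, no measured pair shows this change on its own, so the size of the step is uncertain; since the two substituted compounds 2 and 3 both give lower numbers than compound 1, the step is expected to lower the number, beyond the scatter. For compound 4 the estimate in this assay is 250 nM (range 80 nM to 800 nM), an expected step of a 4.8-fold lower number from compound 1 to compound 4 (0.68 log units; beyond the scatter).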

Compound 4, half-maximal inhibitory concentration: 140 nM
For compound 4 the middle estimate is 1.8-fold (0.25 log units) above the measured one, and the stated range covers the measured number.
By their numbers in this assay, from the lowest: compounds 2, 4 and 3 (each within the scatter of the next); then compound 1.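

Benzylamino in place of hydrogen on the aromatic carbon between two ring nitrogen atoms gives an 8.5-fold lower number from compound 1 to compound 4 (0.93 log units; beyond the scatter) in this assay, the only single-place reading at this position so far. This position therefore accepts a group of this size on the core of compound 1, and the number falls beyond the scatter. No measured evidence bears on the reason for this step.

From the compounds shown here alone, it remains open whether the benzene ring of benzylamino matters, or whether methylamino or the longer phenethylamino on the same carbon would give a similar step.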